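Swapping a Trifluorophenyl Amide for Pyridine: Expected Cytotoxicity

A few compounds are considered here, and "the series" means these few. Any claim that something is new, unique, unknown or untested is made for them only; others in the source may bear on it.

Four compounds share one core, which carries an amide and a second aromatic ring. Compound 1 `CC(C)n1ncc2c(C(=O)Nc3ccccc3F)cc(-c3cccnc3)nc21`, compound 2 `CC(C)n1ncc2c(C(=O)Nc3c(F)cc(F)cc3F)cc(-c3cccs3)nc21` and compound 3 `CC(C)n1ncc2c(C(=O)Nc3ccc(F)cc3)cc(-c3ccco3)nc21` have been tested; compound 4 `CC(C)n1ncc2c(C(=O)Nc3cccnc3)cc(-c3cccs3)nc21` has not. The measure is an ADME assay on LLC-MK2 cells (Macaca mulatta) for cytotoxicity, read by spectrophotometry and crystal violet staining, with a stated time of 4 days; a lower number here means that less compound is tolerated, a higher number that more compound is tolerated. In this assay compound 1 gives 50000 nM. For compound 2 the result in this assay is > 200000 nM, which is a limit of the assay rather than a number. Compound 3 likewise reaches only a limit in this assay, namely > 200000 nM. Compound 2 therefore stands at the limit, a position it shares with compound 3, as the limit of > 200000 nM in this assay, at which 2 of the 3 values shown sit, shows. The change leading to compound 4 is pyridin-3-yl in place of 2,4,6-trifluorophenyl on an amide-type nitrogen. No comparable step has been measured among these compounds. Since compound 2 already sits at the limit (the limit of > 200000 nM in this assay, at which 2 of the 3 values shown sit), the step of an at least 1.6-fold lower number from compound 2 to compound 4 (0.22 log units; that floor lies within the scatter) is expected to be no larger than the usual scatter, and may well end at the limit again. For compound 4 in this assay the expected half-maximal cytotoxic concentration is 120000 nM, between 40000 nM and 200000 nM.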

Compound 4, half-maximal cytotoxic concentration: > 200000 nM
Compound 4: no number, only a limit; the forecaster's own chance of this, stated with the estimate: 55%; middle value at least 1.6-fold (0.22 log units) from the limit.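

Among the compounds shown here, compound 2 and compound 4 both end at a limit of the assay, so no step between them can be read: the limit of > 200000 nM in this assay, at which 3 of the 4 values shown sit. The compounds shown leave open what the true values of compound 2 and compound 4 are, and whether pyridin-3-yl and 2,4,6-trifluorophenyl differ at all in this assay.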